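Notes on a longer side chain in the series

The source may hold more compounds than are shown below. What is called first, only, known or untested is meant among the compounds shown, and "the series" means these compounds.

Among the compounds with values here, in a functional assay on LoVo cells (Homo sapiens) for inhibition, read by MTT assay, with a stated time of 48 h (a higher number here means a weaker inhibitor, a lower number a stronger inhibitor), compound 2 `COc1ccc(N(C)c2nc(C)nc3ccccc23)cc1` gives 8 nM, the lower of the two numbers so far, and compound 1 `COc1ccc(N(C)c2nc(C)nc3ccccc23)cc1OCCCC[Se]C#N` gives 882 nM. Compound 3 `COc1ccc(N(C)c2nc(C)nc3ccccc23)cc1OCCCCC[Se]C#N` departs from compound 2 as follows: a group of 9 heavy atoms (6 carbon, 1 nitrogen, 1 oxygen, 1 selenium; no ring) in place of a hydrogen atom, on an aromatic carbon. Within the data shown here, the one measured step that bears on this is a 110-fold lower number from compound 1 to compound 2 (2.04 log units; beyond the scatter), which is large and removes a shorter chain of the same kind. Read in reverse, it points to a large rise in the number, though no measured pair tests chain length. The expected change is a 110-fold higher number from compound 2 to compound 3 (2.05 log units; beyond the scatter). Compound 3 is estimated at 900 nM, with an expected range of 300 nM to 2500 nM.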

Compound 3, half-maximal inhibitory concentration: 5210 nM
Estimate against measurement, compound 3: 5.8-fold (0.76 log units) below, outside the stated range (above it).
By their numbers in this assay, from the lowest: compound 2; then compound 1; then compound 3.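

In this assay this position is now seen with two chain lengths, with a 650-fold higher number from compound 2 to compound 3 (2.81 log units; beyond the scatter) for adding the chain and a 5.9-fold higher number from compound 1 to compound 3 (0.77 log units; beyond the scatter) for lengthening it. Chain length therefore moves the number by itself, which the earlier pair could not show, and the longer chain gives the higher number of the two. Nothing at hand gives a reason for this rise.

Going by these compounds, whether the rise continues with a still longer chain remains open. So does whether a chain ending in an amine or a carboxylic acid would stay closer to compound 2 8 nM.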